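A few compounds are considered here, and "the series" means these few. Any claim that something is new, unique, unknown or untested is made for them only; others in the source may bear on it.

Compound 2 `CC(=O)N1N=C(c2cc(O)c(O)c([N+](=O)[O-])c2)CC1c1ccoc1` gives 180 nM in an assay for inhibition of Catechol O-methyltransferase (Rattus norvegicus), read by fluorescence and spectrophotometry (a lower number here means a stronger inhibitor, a higher number a weaker inhibitor), within the scatter of compound 1 `CC(=O)N1N=C(c2cc(O)c(O)c([N+](=O)[O-])c2)CC1c1nccs1` at 160 nM; the step of a 1.1-fold higher number from compound 1 to compound 2 (0.05 log units; within the scatter) lies within the scatter. Compound 3 `CC(=O)N1N=C(c2cc(O)c(O)c([N+](=O)[O-])c2)CC1c1cccc(C#N)c1` differs from compound 2 by 3-cyanophenyl in place of furan-3-yl on a saturated ring carbon. Among the compounds with values here, the single measured step also exchanges the group on this saturated ring carbon, one five-membered aromatic ring for another, and it stayed within the scatter; no measured step exchanges a five-membered ring for a six-membered one. Compound 3 is therefore expected to show a step of no change at the digits printed from compound 2 to compound 3 (within the scatter) that does not exceed the scatter. The estimate for compound 3 is 180 nM, with a range from 90 nM to 400 nM.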

Compound 3, half-maximal inhibitory concentration: 79 nM
Beside the measured number, compound 3's estimate is 2.3-fold (0.36 log units) above it; the whole stated range lies above it.
By their numbers in this assay, from the lowest: compound 3; then compounds 1 and 2 (each within the scatter of the next).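

Within the data shown here, on this saturated ring carbon, 3-cyanophenyl is the first group to move the number beyond the scatter in this assay, with modest steps against both five-membered rings (a 2.3-fold lower number from compound 2 to compound 3 (0.36 log units; beyond the scatter); a 2.0-fold lower number from compound 1 to compound 3 (0.31 log units; beyond the scatter)). The position therefore responds to the group it carries, which the exchange of one five-membered aromatic ring for another had not shown. No evidence is available that bears on this result.

The compounds shown leave open whether the six-membered aromatic ring or the nitrile carries the step, a question plain phenyl would separate. Also open, from the compounds shown here alone, is what an amine or a carboxylic acid in place of the nitrile would give.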